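Swapping the Aryl Group on a Shared Thiazolidinone Core

The source may hold more compounds than are shown below. What is called first, only, known or untested is meant among the compounds shown, and "the series" means these compounds.

Compound 1 `CC(C)CN1C(=O)/C(=C/c2ccc(N(C)C)cc2)S/C1=N\c1ccccc1` is weakly cytotoxic: in an ADME assay on HepG2 cells (Homo sapiens) for cytotoxicity, read by MTT assay, with a stated time of 48 h (on this read-out higher numbers stand for weaker inhibition and lower numbers for stronger inhibition), compound 1 gives only a limit of the assay, > 100000 nM, the state described by the limit of > 100000 nM in this assay, at which 1 of the 2 values shown sits. Compound 2 `CC(C)CN1C(=O)/C(=C/c2ccccc2O)S/C1=N\c1ccccc1` was made too, yet in this assay compound 2 has "not determined" (no result reported). Compound 3 `COc1cc(/C=C2\S/C(=N\c3ccccc3)N(CC(C)C)C2=O)ccc1O` differs from compound 1 by 4-hydroxy-3-methoxyphenyl in place of 4-(dimethylamino)phenyl on a double-bonded chain carbon bound to a double-bonded ring carbon. Among the compounds with values here, no measured step between related compounds exists here, so no change beyond the usual scatter is foreseen; the step that the limit leaves unreadable from compound 1 to compound 3 is expected to stay flat. Compound 3 is therefore estimated at 150000 nM, within 40000 nM to 500000 nM, most likely again reported only as a limit.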

Compound 3, half-maximal inhibitory concentration in the HepG2 assay: 89500 nM
For compound 3 the middle estimate is 1.7-fold (0.22 log units) above the measured one; low and high end bracket the measured number.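

In the HepG2 assay, 4-hydroxy-3-methoxyphenyl in place of 4-(dimethylamino)phenyl gives an at least 1.1-fold lower number from compound 1 to compound 3 (0.04 log units; that floor lies within the scatter), so this position now yields a measured number rather than only a limit. Compound 1 still stands at a limit, so the true size of this step cannot be read. In a physicochemical assay for lipophilicity, measured as octanol-water partition (on this read-out lower numbers stand for lower lipophilicity and higher numbers for higher lipophilicity), compound 1 gives 5.49 and compound 3 gives 4.92. The same change does measurably lower lipophilicity: the measured partition coefficient of compound 1, 5.49, and of compound 3, 4.92, a number 0.57 log units lower (beyond the scatter)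

Whether the hydroxy or the methoxy of the entering group accounts for these results on its own stays open. So does the outcome with a carboxylic acid at this place.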